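The compounds below may be only part of what the source reports. "The series", "measured", "known", "first", "only" and "open" are said of these compounds alone.

In an ADME assay on MT4 cells (Homo sapiens) for cytotoxicity, read by MTT assay, with a stated time of 4 days (a lower number here means that less compound is tolerated, a higher number that more compound is tolerated), the compounds measured so far read:

Compound 1 `CCCN(CCC)c1nc(Cc2c(F)cccc2F)c(C)c(=O)[nH]1`: > 74000 nM
Compound 2 `Cc1c(Cc2c(F)cccc2F)nc(N2CCCCC2)[nH]c1=O`: > 78000 nM
Compound 3 `Cc1c(Cc2c(F)cccc2F)nc(N2CCN(C)CC2)[nH]c1=O`: > 75000 nM

All three readings are limits. Compound 3 therefore stands at a limit of > 75000 nM, not at a number. Compound 4 `Cc1c(Cc2c(F)cccc2F)nc(N2CCN(c3ccccn3)CC2)[nH]c1=O` carries pyridin-2-yl in place of methyl on an amine nitrogen in a ring. Going by the values given here, only two measured steps lead to compound 3, and both exchange the whole amine: a step that the two limits leave unreadable from compound 1 to compound 3 and a step that the two limits leave unreadable from compound 2 to compound 3. Neither has a readable size, so they offer no measured guide to this change. No change beyond the scatter is expected in this assay. The expected result is an at least 1.2-fold lower number from compound 3 to compound 4 (0.09 log units; that floor lies within the scatter). For compound 4 the estimate is 60000 nM, with an expected range of 20000 nM to 100000 nM.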

Compound 4, half-maximal cytotoxic concentration: > 63000 nM
Compound 4 gave a limit, no number (the forecaster's own chance of this, stated with the estimate: 65%); middle value at least 1.0-fold (0.02 log units) away from the limit.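

Compound 3 and compound 4 both stand only as limits in this assay, so no step can be read between them. The compounds shown leave open the actual half-maximal cytotoxic concentration of each one.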